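Dibromo enol lactone series: acetoxy removal at the chain

This account rests on a few compounds, and the source may have more. Where it says the series, first, only, none or still open, it means among the compounds named here.

Measured so far:
- Compound 1 `CCC[C@@H](OC(C)=O)C1=C(Br)/C(=C/Br)OC1=O`: 0.5 ug/mL
- Compound 2 `CCC[C@@H](OC(C)=O)C1=C(Br)[C@@](CI)(OC)OC1=O`: 12.9 ug/mL

In a functional assay on LNCaP cells (Homo sapiens) for cytotoxicity (a higher number here means that more compound is needed for the effect, a lower number that less compound is needed), compound 1 gives 0.5 ug/mL, the lowest of the two numbers at hand. The nearest measured neighbour is compound 2, which in this assay gives 12.9 ug/mL, a higher number that lies beyond the usual scatter. For the measured compounds named here, compound 2 differs from compound 1 in more than one place, so no single step between the two can be read from their values; they show only that the shared core tolerates large swings in the read-out.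

Compound 3 `CCCCC1=C(Br)/C(=C/Br)OC1=O` has not yet been measured in this assay. Relative to compound 1 it carries hydrogen in place of acetoxy on a saturated chain carbon bound to a double-bonded ring carbon and a saturated chain carbon. Going by the values given here, no measured pair isolates this change, so the direction of the step rests on nothing firmer than the absence of a comparable precedent. The step from compound 1 to compound 3 in this assay is expected to be small, at most a modest rise, with a 2.0-fold higher number from compound 1 to compound 3 (0.30 log units; within the scatter) as the working guess. For compound 3 the expected value in this assay is 1 ug/mL, with a plausible range from 0.3 ug/mL to 4 ug/mL.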

Compound 3, concentration for half-maximal effect: 7.3 ug/mL
Compound 3: middle estimate off by 7.3-fold (0.86 log units), on the low side; the whole stated range lies below it.
By their numbers in this assay, from the lowest: compound 1; then compounds 3 and 2 (each within the scatter of the next).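

In this assay, for the compounds shown here, hydrogen in place of acetoxy on a saturated chain carbon bound to a double-bonded ring carbon and a saturated chain carbon gives a 15-fold higher number from compound 1 to compound 3 (1.16 log units; beyond the scatter), and this is the first step that isolates a single change. The chain position is therefore not indifferent to what it carries: with the rest of the structure unchanged, compound 1 with its acetoxy group needs less compound for the effect than compound 3 with hydrogen. Nothing at hand bears on the cause of this large step, so it stands as an observation only.

Going by these compounds, it remains open whether the acetoxy group is specifically required or whether a hydroxyl, a methoxy or a longer ester such as butyryloxy on the same carbon would give a value close to that of compound 1. Also unresolved are whether the step carries over to the core of compound 2 and whether the opposite configuration at the acetoxy-bearing carbon would keep the number as low.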